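Swapping the isobutylsulfanyl chain for allyloxy

The source may report more compounds than this note shows. Statements on the series, on what has been measured and on what is new or still open speak of the compounds shown alone.

Compound 1 `Nc1nc(OCC(F)(F)F)c2ncn(/C=C3/CC3(CO)CO)c2n1` and compound 2 `CC(C)CSc1nc(N)nc2c1ncn2/C=C1/CC1(CO)CO` share one core and were both tested in an ADME assay on HFF cells (Homo sapiens) for cytotoxicity, with a stated time of 8 days; on this read-out higher numbers stand for lower toxicity in this test and lower numbers for higher toxicity in this test. Compound 1 gives > 300000 nM, which is a limit of the test and not a number. Compound 2 gives > 300000 nM, which is also a limit. Going by the values given here, compound 2 therefore has no exact position, and the only other value beside it is a limit too.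

Among the compounds with values here, the one measured step, a step that the two limits leave unreadable from compound 1 to compound 2, is isobutylsulfanyl in place of 2,2,2-trifluoroethoxy on an aromatic carbon. Its size cannot be read. The evidence for what such a swap does is thin, since it comes down to the limit of > 300000 nM in this assay, at which 2 of the 2 values shown sit.

Compound 3 `C=CCOc1nc(N)nc2c1ncn2/C=C1/CC1(CO)CO` changes that same carbon again, with allyloxy in place of isobutylsulfanyl on an aromatic carbon. Neither measured compound gives a reason to expect a change in this assay, so no step beyond the scatter is anticipated. The expected step is a number no higher from compound 2 to compound 3 (the limit leaves the size open). For compound 3 the estimated value is 300000 nM, with an expected range from 100000 nM to 400000 nM, and the result may well be only a limit again.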

Compound 3, half-maximal cytotoxic concentration: > 300000 nM
Compound 3 gave a limit, no number; the forecaster's own chance of this, stated with the estimate: 75%; the middle value sits exactly at the limit.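

Compound 3, like compound 1 and compound 2, gives only a limit and not a number in this assay, so no new step among these compounds can be read. The compounds shown leave open whether trifluoroethoxy, isobutylsulfanyl and allyloxy on that aromatic carbon differ at all in this test, as all that can be read is this: the limit of > 300000 nM in this assay, at which 3 of the 3 values shown sit.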